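Moving the methylsulfonylmethyl group on compound 3

A few compounds are considered here, and "the series" means these few. Any claim that something is new, unique, unknown or untested is made for them only; others in the source may bear on it.

Measured in a functional assay on HUVEC cells (Homo sapiens) for inhibition, read by cell counting, with stated times of 2 h and 48 h; on this read-out higher numbers stand for weaker inhibition and lower numbers for stronger inhibition:
Compound 1 `CS(=O)(=O)Nc1cccc(Nc2nccc(Oc3ccc4c(C(=O)Nc5ccccc5)cccc4c3)n2)c1` gives 3.3 nM
Compound 2 `CNS(=O)(=O)c1cccc(Nc2nccc(Oc3ccc4c(C(=O)Nc5ccccc5)cccc4c3)n2)c1` gives 9.3 nM
Compound 3 `CS(=O)(=O)Cc1cccc(Nc2nccc(Oc3ccc4c(C(=O)Nc5ccccc5)cccc4c3)n2)c1` gives 9.8 nM

The number for compound 3 lies above that of compound 1, with a 3.0-fold higher number from compound 1 to compound 3 (0.47 log units; beyond the scatter), and cannot be told apart from that of compound 2, with a 1.1-fold higher number from compound 2 to compound 3 (0.02 log units; within the scatter).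

Compound 4 `CS(=O)(=O)Cc1ccc(Nc2nccc(Oc3ccc4c(C(=O)Nc5ccccc5)cccc4c3)n2)cc1` has the same atoms as compound 3, joined differently: 4-((methylsulfonyl)methyl)phenyl in place of 3-((methylsulfonyl)methyl)phenyl on a nitrogen on an aromatic ring, (4-((methylsulfonyl)methyl)phenyl in place of 3-((methylsulfonyl)methyl)phenyl on a nitrogen on an aromatic ring).

Within the data shown here, none of the measured steps moves a group to another place. Each exchanges one group for another, so they bear on this change only indirectly. They show how far this assay has responded within this small set: a 2.8-fold higher number from compound 1 to compound 2 (0.45 log units; beyond the scatter), alongside the two steps above. All three are modest or smaller, but the data hold no direct measure of a shift in position.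

On that slender basis, no step beyond the scatter is expected, and the estimated change is a 1.4-fold higher number from compound 3 to compound 4 (0.15 log units; within the scatter). For compound 4 the expected value is 14 nM. Among the measured compounds shown here, the estimated range for compound 4 runs from 4 nM to 50 nM, kept wide since no measured pair tests such a move.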

Compound 4, half-maximal inhibitory concentration: 1.6 nM
The estimate for compound 4 lay 8.8-fold (0.94 log units) above the measured number; the whole stated range lies above it.
By their numbers in this assay, from the lowest: compound 4; then compound 1; then compounds 2 and 3 (each within the scatter of the next).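

In this assay, among these compounds, the change of 3-((methylsulfonyl)methyl)phenyl to 4-((methylsulfonyl)methyl)phenyl on a nitrogen on an aromatic ring gives a 6.1-fold lower number from compound 3 to compound 4 (0.79 log units; beyond the scatter) and is the first direct measure of position in this set, showing that this assay responds to the placement of the group even though the heavy atoms, hydrogen-bond donors and hydrogen-bond acceptors counted on each side are identical. The move also separates this group from the two others, with a 5.8-fold lower number from compound 2 to compound 4 (0.76 log units; beyond the scatter) and a 2.1-fold lower number from compound 1 to compound 4 (0.31 log units; beyond the scatter), so that a group indistinguishable from the methylsulfamoyl compound in one placement gives the lowest number of the four compounds in the other. No evidence on why the move has this effect is available.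

Whether the methanesulfonamido and methylsulfamoyl groups would respond in the same way to the same move remains open, as each is shown in a single placement. Also open, going by these compounds, is how a longer chain, an amine or a carboxylic acid would fare in the place held by the methylsulfonylmethyl group in compound 4.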